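Replacing 2-fluorophenyl while keeping the 2-hydroxyphenyl group

The source may hold more compounds than are shown below. What is called first, only, known or untested is meant among the compounds shown, and "the series" means these compounds.

In a functional assay on DU-145 cells (Homo sapiens) for inhibition (on this read-out lower numbers stand for stronger inhibition and higher numbers for weaker inhibition), compound 1 (`Oc1ccc(-c2cc(-c3ccccc3F)cc(-c3ccccc3O)n2)cc1`) gives > 50000 nM as a limit and not as a number. Compound 1 therefore stands at the limit of > 50000 nM in this assay, at which 1 of the 2 values shown sits, and has no exact starting value. Compound 2 (`Oc1ccc(-c2cc(-c3ccccc3F)cc(-c3cccc(O)c3)n2)cc1`) gives 3160 nM in this assay as a measured number. Within the data shown here, the only measured step is an at least 15-fold lower number from compound 1 to compound 2 (1.19 log units; beyond the scatter) and comes from 3-hydroxyphenyl in place of 2-hydroxyphenyl on an aromatic carbon.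

Compound 3 (`Oc1ccc(-c2cc(-c3cccc(C(F)(F)F)c3)cc(-c3ccccc3O)n2)cc1`) keeps the 2-hydroxyphenyl group of compound 1 and instead carries 3-(trifluoromethyl)phenyl in place of 2-fluorophenyl on the aromatic carbon opposite the ring nitrogen (3-(trifluoromethyl)phenyl in place of 2-fluorophenyl on an aromatic carbon). The measured step concerns a different group, so it bears only indirectly and sets no size for this change. It does show that one replacement can carry compound 1 well clear of the limit. A smaller shift towards stronger inhibition is expected here, and no shift beyond the limit is also possible. The expected change is an at least 2.7-fold lower number from compound 1 to compound 3 (0.44 log units; beyond the scatter) in this assay on this estimate. The estimate for compound 3 is 18000 nM with an expected range from 4000 nM to 50000 nM in this assay.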

Compound 3, half-maximal inhibitory concentration: > 50000 nM
Compound 3: only a limit was reported; the forecaster's own chance of this, stated with the estimate: 35%; at least 2.7-fold (0.44 log units) between middle value and limit.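

In this assay, compound 1 and compound 3 both stand at a limit and not at a number, so the step between them cannot be read: the limit of > 50000 nM in this assay, at which 2 of the 3 values shown sit. The compounds shown leave open how far beyond the limit either compound lies, and whether 3-(trifluoromethyl)phenyl in place of 2-fluorophenyl changes inhibition at all.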